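The compounds below may be only part of what the source reports. "The series", "measured", "known", "first", "only" and "open" are said of these compounds alone.

Within the data shown here, compound 2 `Cc1ccncc1-c1cccc2c1cnn2-c1ccccc1` holds the highest of the two numbers so far in an assay on HEK293 cells for inhibition of steroid 17-alpha-hydroxylase/17,20 lyase (Homo sapiens), read by scintillation proximity assay, using microsomes and NADPH, with a stated time of 45 min (a lower number here means a stronger inhibitor, a higher number a weaker inhibitor), where compound 2 gives 4 nM; its nearest neighbour, compound 1 `Cc1ccncc1-c1cccc2c1cnn2-c1cccnn1`, gives 3 nM, and a 1.3-fold higher number from compound 1 to compound 2 (0.12 log units; within the scatter). Compound 3 `Cc1ccncc1-c1cccc2c1cnn2-c1ccc(F)cc1` is unmeasured. The change from compound 2 is fluoro in place of hydrogen on an aromatic carbon. Among the measured compounds shown here, no measured step covers this kind of change; the single step, a 1.3-fold higher number from compound 1 to compound 2 (0.12 log units; within the scatter), concerns the ring on the aromatic nitrogen and stays within the scatter, so no shift beyond the scatter is expected in this assay. Compound 3 is expected at 4 nM, between 1.5 nM and 10 nM. The expected step is no change at the digits printed from compound 2 to compound 3 (within the scatter).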

Compound 3, half-maximal inhibitory concentration: 5 nM
The estimate for compound 3 lay 1.3-fold (0.10 log units) below the measured number; the measured number falls inside the stated range.
By their numbers in this assay, from the lowest: compounds 1, 2 and 3 (each within the scatter of the next).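

In this assay, among these compounds, fluoro in place of hydrogen on an aromatic carbon, para to a large group, gives a first reading at this position (a 1.3-fold higher number from compound 2 to compound 3 (0.10 log units; within the scatter)), and the step stays within the scatter. Taken together with the ring change on the aromatic nitrogen (a 1.7-fold higher number from compound 1 to compound 3 (0.22 log units; within the scatter)), 4-fluorophenyl also stays within the scatter of pyridazin-3-yl. No available data bear on what lies behind these results.

Open, going by these compounds, is whether an amine, a carboxylic acid or a methoxy group at this position would shift the number beyond the scatter. Also open, on these data alone, is whether fluoro on another carbon of the phenyl ring would do so.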